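Bromo to trifluoromethyl on a shared indazole-free core

This account rests on a few compounds, and the source may have more. Where it says the series, first, only, none or still open, it means among the compounds named here.

Of the compounds shown here, three with a shared core have been measured so far in an assay for inhibition of Tryptophan 2,3-dioxygenase (Homo sapiens), with stated times of 10 min and 60 min; on this read-out lower numbers stand for stronger inhibition and higher numbers for weaker inhibition. Compound 1 `O=[N+]([O-])c1cc(OCc2ccccc2)ccc1CNc1cc(C(F)(F)F)cc2[nH]ncc12` gives 97000 nM. Compound 2 `Oc1ccc(CNc2cc(C(F)(F)F)cc3[nH]ncc23)c(Cl)c1` gives 2680 nM. Compound 3 `O=[N+]([O-])c1cccc(CNc2cc(Br)cc3[nH]ncc23)c1` gives 1600 nM. Among the three numbers, that of compound 3 is the lowest, but compound 2 sits within the usual scatter of it, so the two cannot be told apart on this read-out; compound 1 lies well beyond the scatter and stands clearly apart from both.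

Compound 4 `O=[N+]([O-])c1cccc(CNc2cc(C(F)(F)F)cc3[nH]ncc23)c1` has not yet been measured in this assay. It differs from compound 3 in one place: trifluoromethyl in place of bromo on an aromatic carbon. Compounds 1 and 2 already carry the trifluoromethyl group on the same core, and compound 2 reaches 2680 nM with it, a number within the scatter of what compound 3 shows with the bromo group. No change beyond the scatter is therefore expected from the step, in either direction. In this assay compound 4 is estimated at 2000 nM, with a range from 600 nM to 7000 nM. The step this estimate implies, a 1.3-fold higher number from compound 3 to compound 4 (0.10 log units; within the scatter), is expected to be small.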

Compound 4, half-maximal inhibitory concentration: 5170 nM
Estimate against measurement, compound 4: 2.6-fold (0.41 log units) below; the range from low to high includes it.
By their numbers in this assay, from the lowest: compounds 3, 2 and 4 (each within the scatter of the next, the first and the last beyond it); then compound 1.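

Among the compounds shown here, compound 3 and compound 4 are the first pair in this set that differ in one place, so the exchange of bromo for trifluoromethyl on this aromatic carbon can now be read directly: in this assay the change gives a 3.2-fold higher number from compound 3 to compound 4 (0.51 log units; beyond the scatter). The position is therefore not indifferent to this exchange, although the modest step shows that a group of four heavy atoms can stand where a single bromine stood while the number stays in the same general range. Nothing available accounts for the direction or size of this step.

From the compounds shown here alone, with only these two groups compared directly at this carbon, it remains open whether a nitrile, a methoxy group or a plain hydrogen there would give a lower or a higher number than bromo. Going by these compounds, it is also open whether the step would keep its size with other substituents on the outer benzene ring, such as the hydroxy and chloro groups of compound 2 or the benzyloxy group of compound 1.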